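Arylamino to piperidin-1-yl on the shared core

The compounds below may be only part of what the source reports. "The series", "measured", "known", "first", "only" and "open" are said of these compounds alone.

- Compound 1 `O=C1C=C(N2CCC2)C(=O)c2c1nc1n2[C@H]2OC[C@@H](O)[C@H]2OC1`: > 16000 nM
- Compound 2 `COc1ccc(NC2=CC(=O)c3nc4n(c3C2=O)[C@H]2OC[C@@H](O)[C@H]2OC4)cc1`: 1680 nM
- Compound 3 `Cc1ccc(NC2=CC(=O)c3nc4n(c3C2=O)[C@H]2OC[C@@H](O)[C@H]2OC4)cc1C`: 860 nM

All three were tested in a functional assay on MGC-803 cells (Homo sapiens) for inhibition, read by sulforhodamine B assay; a lower number here means a stronger inhibitor, a higher number a weaker inhibitor. For compound 1, the entry > 16000 nM is a limit of the assay and not a number. Among the measured compounds shown here, compound 3 sits level with compound 2, the only other compound with a numeric value, and the gap is a 2.0-fold lower number from compound 2 to compound 3 (0.29 log units; within the scatter).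

The next change leads to compound 4 `O=C1C=C(N2CCCCC2)C(=O)c2c1nc1n2[C@H]2OC[C@@H](O)[C@H]2OC1`: piperidin-1-yl in place of (3,4-dimethylphenyl)amino on a double-bonded ring carbon. The closest measured change is azetidin-1-yl giving way to the same (3,4-dimethylphenyl)amino, which gave an at least 18-fold lower number from compound 1 to compound 3 (1.26 log units; beyond the scatter). The (4-methoxyphenyl)amino counterpart gave an at least 9.5-fold lower number from compound 1 to compound 2 (0.97 log units; beyond the scatter). Both steps start from a limit, so their true sizes are open. Compound 4 reverses this kind of change, with a different ring amine, so a clear rise in this assay is expected. The expected step is a 10-fold higher number from compound 3 to compound 4 (1.02 log units; beyond the scatter). The estimate for compound 4 is 9000 nM, with an expected range of 2500 nM to 32000 nM.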

Compound 4, half-maximal inhibitory concentration: > 8000 nM
Compound 4 ended at the assay's limit (the forecaster's own chance of this, stated with the estimate: 45%); the middle value is on the limit's open side.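

In this assay, the entry for compound 4 is a limit of the assay and not a number: the limit of > 8000 nM in this assay, at which 1 of the 4 values shown sits.

With piperidin-1-yl on the double-bonded ring carbon, the steps are an at least 9.3-fold higher number from compound 3 to compound 4 (0.96 log units; beyond the scatter) and an at least 4.7-fold higher number from compound 2 to compound 4 (0.67 log units; beyond the scatter), so a second ring amine, after azetidin-1-yl in compound 1, also ends at a limit, whereas both arylamino groups give numeric values. The step from compound 1 to compound 4 joins two limits and cannot be read: the limit of > 16000 nM in this assay, at which 1 of the 4 values shown sits.

The change from compound 3 to compound 4 removes the aromatic ring and the hydrogen-bond donor together, leaving open which of them matters; cyclohexylamino and methyl(phenyl)amino would separate the two. As far as these compounds go, the true sizes of both readable steps also remain open, as each ends at a limit.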